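A few compounds are considered here, and "the series" means these few. Any claim that something is new, unique, unknown or untested is made for them only; others in the source may bear on it.

Compound 1 `COc1cc(Nc2nc(C)cc(N(C)C)n2)ccc1F` gives > 250000 nM in a physicochemical assay for solubility, read by nephelometry, measured as kinetic solubility (on this read-out lower numbers stand for lower solubility and higher numbers for higher solubility), which is a limit of the assay rather than a number.
Compound 2 `CCOC1CCCN(c2cc(C)nc(Nc3ccc(F)c(OC)c3)n2)C1` gives > 250000 nM in this assay, again a limit rather than a number.

Compound 2 therefore stands at the limit of this assay, as the limit of > 250000 nM in this assay, at which 2 of the 2 values shown sit, shows. Because both measured values are limits, no ordering between compound 1 and compound 2 can be read from them. Compound 3 `COc1cc(Nc2nc(C)cc(N3CCCC(C#N)C3)n2)ccc1F` has not yet been measured. It differs from compound 2 by cyano in place of ethoxy on a saturated ring carbon. Going by the values given here, no step between measured compounds is available to guide the size of this change, so no shift beyond the usual scatter is assumed. The value for compound 3 in this assay is expected to be 250000 nM, in the range from 100000 nM to 500000 nM. The expected step from compound 2 to compound 3 is accordingly estimated as a number no higher from compound 2 to compound 3 (the limit leaves the size open), nothing beyond the scatter.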

Compound 3, solubility: 219000 nM
For compound 3 the middle estimate is 1.1-fold (0.06 log units) above the measured one, and the stated range covers the measured number.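

In this assay, cyano in place of ethoxy on a saturated ring carbon gives this series its first value that is a number and not a limit, and the change amounts to an at least 1.1-fold lower number from compound 2 to compound 3 (0.05 log units; that floor lies within the scatter). Seen from the smaller compound, 3-cyanopiperidin-1-yl in place of dimethylamino on an aromatic carbon amounts to an at least 1.1-fold lower number from compound 1 to compound 3 (0.05 log units; that floor lies within the scatter). From the compounds shown here alone, neither floor goes beyond the scatter, and the true size of both steps stays open because their starting values are limits of the assay: the limit of > 250000 nM in this assay, at which 2 of the 3 values shown sit.

The compounds shown leave open how an amine, a carboxylic acid or a longer chain on the same saturated ring carbon would read in this assay. They also leave open whether a change starting from a number, rather than from a limit, would go beyond the scatter.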